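Hydroxamate series: methoxy to tert-butyl on two cores

The source may report more compounds than this note shows. Statements on the series, on what has been measured and on what is new or still open speak of the compounds shown alone.

Compound 1 `COc1ccc(CN2CC(=O)N(Cc3ccc(C(=O)NO)cc3)C2=O)cc1` and compound 2 `CC(C)(C)c1ccc(CN2CC(=O)N(Cc3ccc(C(=O)NO)cc3)C2=O)cc1` share one core, while compound 3 `COc1ccc(CC2(c3ccccc3)NC(=O)N(Cc3ccc(C(=O)NO)cc3)C2=O)cc1` and compound 4 `CC(C)(C)c1ccc(CC2(c3ccccc3)NC(=O)N(Cc3ccc(C(=O)NO)cc3)C2=O)cc1` share another; the difference between the two cores is not broken down here. In an assay on isolated protein for inhibition of protein deacetylase HDAC6 (Homo sapiens), read by fluorescence, with stated times of 10 min and 2 h (a higher number here means a weaker inhibitor, a lower number a stronger inhibitor), compound 1 gives 28.2 nM, and compound 2 gives 40.7 nM. The change between them, (tert-butyl in place of methoxy on an aromatic carbon), gave a 1.4-fold higher number from compound 1 to compound 2 (0.16 log units; within the scatter). In this assay compound 3 gives 72.4 nM; its gap to compound 2 lies within the scatter, its gap to compound 1 beyond it. Compound 4 carries the same change on the core of compound 3: tert-butyl in place of methoxy on an aromatic carbon, at a place described in the same words as before, so it counts as the same change. Among the measured compounds shown here, only one measured pair shows it, so the expectation for compound 4 rests on that pair alone. For the measured compounds named here, for compound 4 the step of a 1.4-fold higher number from compound 3 to compound 4 (0.14 log units; within the scatter) is expected in this assay, because the only measured instance of this change is a 1.4-fold higher number from compound 1 to compound 2 (0.16 log units; within the scatter). Compound 4 is thus estimated at 100 nM in this assay, with a range from 50 nM to 220 nM.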

Compound 4, half-maximal inhibitory concentration: 115 nM
Beside the measured number, compound 4's estimate is 1.2-fold (0.06 log units) below it; the range from low to high includes it.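

In this assay, tert-butyl in place of methoxy on an aromatic carbon gives a 1.6-fold higher number from compound 3 to compound 4 (0.20 log units; within the scatter), and this step does not differ from the earlier one on the other core: the same change on two cores in this assay, a 1.4-fold higher number (0.16 log units; within the scatter) from compound 1 to compound 2 and a 1.6-fold higher number (0.20 log units; within the scatter) from compound 3 to compound 4, 1.1-fold (0.04 log units) apart, within the scatter of two such steps. Across these two cores, then, the change carries over with no detectable difference in the size of its step. It does not show that the change has a real effect on the read-out in either core: each step lies within the scatter, and two pairs say nothing about a third core or about any other assay.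

The compounds shown leave open whether a different group on this aromatic carbon, such as an amine, a carboxylic acid or a longer chain, would give a step beyond the scatter on either core. They also leave open which structural differences between the two cores account for any gap between them, as no pair here separates those differences one at a time.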